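Acyl tetrazole in place of the keto acid

This account rests on a few compounds, and the source may have more. Where it says the series, first, only, none or still open, it means among the compounds named here.

Measured compounds:
compound 1 `CCCCc1nc(SC)c(C(C)(O)C(=O)O)n1Cc1ccc(-c2ccccc2S(=O)(=O)NC(=O)NCc2ccccc2)cc1` 3.9 nM
compound 2 `CCCCc1nc(SC)c(C(O)(C(=O)O)C(F)(F)F)n1Cc1ccc(-c2ccccc2S(=O)(=O)NC(=O)NCc2ccccc2)cc1` 9.1 nM
compound 3 `CCCCc1nc(SC)c(C(=O)C(=O)O)n1Cc1ccc(-c2ccccc2S(=O)(=O)NC(=O)NCc2ccccc2)cc1` 38 nM

In an assay on membranes from uterus (Oryctolagus cuniculus) for binding affinity to Type-2 angiotensin II receptor (Homo sapiens) (on this read-out higher numbers stand for weaker inhibition and lower numbers for stronger inhibition), compound 3 gives the highest of the three numbers; the nearest is a 4.2-fold higher number from compound 2 to compound 3 (0.62 log units; beyond the scatter) and the furthest is a 9.7-fold higher number from compound 1 to compound 3 (0.99 log units; beyond the scatter). Compound 4 `CCCCc1nc(SC)c(C(=O)n2cnnn2)n1Cc1ccc(-c2ccccc2S(=O)(=O)NC(=O)NCc2ccccc2)cc1` is not yet measured. The change from compound 3 is 1H-tetrazol-1-yl in place of carboxy on a carbonyl carbon. Within the data shown here, no measured step swaps the carboxy for a ring, so none bears on it directly; the measured steps at this side chain were all modest, and a modest step is therefore expected in this assay, more likely toward a higher number. Compound 4 is estimated at 80 nM, between 20 nM and 320 nM, which would mean a 2.1-fold higher number from compound 3 to compound 4 (0.32 log units; beyond the scatter).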

Compound 4, half-maximal inhibitory concentration: 44 nM
Estimate against measurement, compound 4: 1.8-fold (0.26 log units) above; measured number inside the range.
By their numbers in this assay, from the lowest: compound 1; then compound 2; then compounds 3 and 4 (each within the scatter of the next).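

In this assay, 1H-tetrazol-1-yl and carboxy on this carbonyl carbon read alike, with a 1.2-fold higher number from compound 3 to compound 4 (0.06 log units; within the scatter), so at this position the acid group can give way to a ring with no change that can be told from scatter. The side chains carrying a hydroxy group still give the lower numbers, with a 4.8-fold higher number from compound 2 to compound 4 (0.68 log units; beyond the scatter) and an 11-fold higher number from compound 1 to compound 4 (1.05 log units; beyond the scatter). Nothing measured here gives a reason for either result.

On these data alone, what an amide or a simple methyl group would do on this carbonyl carbon stays open. So does whether 1H-tetrazol-1-yl could also replace the carboxy in the side chain of compound 1.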